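Swapping one aryl group on a weakly cytotoxic compound

This account rests on a few compounds, and the source may have more. Where it says the series, first, only, none or still open, it means among the compounds named here.

Measured in an ADME assay on KB cells (Homo sapiens) for cytotoxicity, read by MTT assay, with a stated time of 72 h; a lower number here means a stronger inhibitor, a higher number a weaker inhibitor:
- Compound 1 `COc1ccc(C2=C(c3cc(OC)c(OC)c(OC)c3)C(=O)C(OC(C)=O)C2)cc1`: 72 ug/mL
- Compound 2 `COc1ccc(C2=C(c3cc(OC)c(OC)c(OC)c3)C(=O)CC2O[SiH2]C(C)(C)C)cc1`: > 100 ug/mL

The reading for compound 2 is a limit of the assay, not a number. Compound 3 `COc1ccc(OC)c(C2=C(c3cc(OC)c(OC)c(OC)c3)C(=O)CC2O[SiH2]C(C)(C)C)c1` has 2,5-dimethoxyphenyl in place of the 4-methoxyphenyl of compound 2, on a double-bonded ring carbon: 2,5-dimethoxyphenyl in place of 4-methoxyphenyl on a double-bonded ring carbon. Within the data shown here, no measured pair shows what this swap does, so the only guide is compound 2 at > 100 ug/mL. The expected change is no larger than the usual scatter, a number no higher from compound 2 to compound 3 (the limit leaves the size open). The estimate for compound 3 is 100 ug/mL, with an expected range of 40 ug/mL to 200 ug/mL.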

Compound 3, half-maximal inhibitory concentration: 10 ug/mL
Compound 3: middle estimate off by 10-fold (1.00 log units), on the high side; measured number below the stated range.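

In this assay, the aryl group on this double-bonded ring carbon matters: 2,5-dimethoxyphenyl in place of 4-methoxyphenyl gives an at least 10-fold lower number from compound 2 to compound 3 (1.00 log units; beyond the scatter). Compound 1 and compound 2 could not show that a change at this position moves the number beyond the scatter. The true size of the step stays open, as one end of it is a limit of the assay and not a number: the limit of > 100 ug/mL in this assay, at which 1 of the 3 values shown sits.

The compounds shown leave open whether both methoxy groups of the 2,5-dimethoxyphenyl are needed for this drop. They also leave open how an amine or a carboxylic acid on this aromatic ring would behave.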